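The source may hold more compounds than are shown below. What is called first, only, known or untested is meant among the compounds shown, and "the series" means these compounds.

Measured so far in a functional assay on L02 cells (Homo sapiens) for inhibition, read by MTT assay, with a stated time of 48 h; a lower number here means a stronger inhibitor, a higher number a weaker inhibitor:

Compound 1 `COc1ccc2c(=O)c(/C=C/C(=O)Nc3cccc(C)c3)coc2c1` gives > 200000 nM, a limit of the assay rather than a number.
Compound 2 `COc1ccc2c(=O)c(/C=C/C(=O)Nc3cccc(Cl)c3)coc2c1` gives > 200000 nM, again a limit.
Compound 3 `COc1ccc2c(=O)c(/C=C/C(=O)Nc3ccccc3)coc2c1` gives > 200000 nM, also a limit.

Compound 3 thus stands nowhere that can be placed on a scale: its value in this assay is a limit, and the two other values are limits as well. The steps among the measured compounds say nothing readable about size: a step that the two limits leave unreadable from compound 1 to compound 2, a step that the two limits leave unreadable from compound 1 to compound 3 and a step that the two limits leave unreadable from compound 2 to compound 3. All three values sit at the same point, (the limit of > 200000 nM in this assay, at which 3 of the 3 values shown sit).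

Compound 4 `COc1ccc2c(=O)c(/C=C/C(=O)Nc3ccccc3Cl)coc2c1` differs from compound 3 in one place: chloro in place of hydrogen on an aromatic carbon. Going by the values given here, the only measured steps that bear on it are the three above, each unreadable, and a chloro already entering on the same ring in compound 2 left the value at a limit. No step beyond the scatter is therefore expected in this assay; the step expected from the change is a step that the limit leaves unreadable from compound 3 to compound 4. For compound 4 the estimate is 300000 nM, within 100000 nM to 1000000 nM, most probably reported once more as a limit.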

Compound 4, half-maximal inhibitory concentration: > 200000 nM
Compound 4 was reported as a limit; the forecaster's own chance of this, stated with the estimate: 85%; the middle value lies beyond the limit too.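

In this assay compound 4 gives > 200000 nM as a limit of the assay and not a number. Its steps from compound 1, compound 2 and compound 3 therefore cannot be read, and all the results sit together: the limit of > 200000 nM in this assay, at which 4 of the 4 values shown sit. The compounds shown leave open whether any of them has a value that can be placed on a scale in this assay.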